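Trimming One Chloro From a Triazole-Linked Enone

The source may report more compounds than this note shows. Statements on the series, on what has been measured and on what is new or still open speak of the compounds shown alone.

Compound 1 `C#CCOc1ccc(/C=C/C(C)=O)cc1OC`: 40200 nM
Compound 2 `COc1cc(/C=C/C(C)=O)ccc1OCc1cn(-c2c(Cl)cccc2Cl)nn1`: 3070 nM

Both numbers come from a functional assay on PC-3 cells (Homo sapiens) for antiproliferative activity, read by MTT assay, with a stated time of 48 h; a higher number here means a weaker inhibitor, a lower number a stronger inhibitor. Among the measured compounds shown here, compound 2 stands lowest of the two values; the only other number, that of compound 1, lies higher by a gap beyond the usual scatter. No pair of measured compounds differs in a single place, so the two values are read only as what they show, and nothing is said about why they differ.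

Compound 3 `COc1cc(/C=C/C(C)=O)ccc1OCc1cn(-c2ccccc2Cl)nn1` has not yet been measured. It differs from compound 2 by hydrogen in place of chloro on an aromatic carbon; cut one bond further out, the change reads 2,6-dichlorophenyl to 2-chlorophenyl. With no measured step of this kind in hand, the step of a 1.5-fold higher number from compound 2 to compound 3 (0.17 log units; within the scatter) is expected to be small, at most a little beyond the scatter, towards a higher number. Compound 3 is therefore estimated in this assay at 4500 nM, with a range from 1500 nM to 14000 nM.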

Compound 3, half-maximal inhibitory concentration: 48000 nM
Compound 3: the middle estimate sits 11-fold (1.03 log units) below what was measured; measured number outside the range, above it.
By their numbers in this assay, from the lowest: compound 2; then compounds 1 and 3 (each within the scatter of the next).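

In this assay, the single change from 2,6-dichlorophenyl to 2-chlorophenyl is a large one, a 16-fold higher number from compound 2 to compound 3 (1.19 log units; beyond the scatter), and it is the only step shown between compounds that differ in one place. It shows that this aromatic carbon, ortho to a large group and meta to a chloro group, is not a neutral site in this series: hydrogen in place of chloro there, one heavy atom lost, is enough to move the value well beyond the scatter. Nothing available accounts for why this one chloro matters so much.

As far as these compounds go, whether chloro itself is needed at this carbon stays open, since a fluoro or a methyl group there could tell a demand for chloro from a demand for any group other than hydrogen. The compounds shown also leave open what the remaining chloro contributes, as both keep it.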